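The source may hold more compounds than are shown below. What is called first, only, known or untested is meant among the compounds shown, and "the series" means these compounds.

Compound 1 `COC(=O)CC(=O)NC1=CS(=O)(=O)O[C@@]12[C@@H](CO[Si](C)(C)C(C)(C)C)O[C@@H](n1cc(C)c(=O)n(C)c1=O)[C@@H]2O[Si](C)(C)C(C)(C)C` is the reference point here. In a functional assay on CCRF-CEM cells (Homo sapiens) (a higher number here means that more compound is tolerated, a lower number that less compound is tolerated), compound 1 gives 29700 nM, the lowest of the two plain numbers in this set; its nearest neighbour is compound 3 `Cc1cn([C@@H]2O[C@@H]3COC4(O)CS(=O)(=O)O[C@@]34[C@H]2O)c(=O)[nH]c1=O`, which in this assay gives 100000 nM. Compound 2 `COC(=O)CCNC1=CS(=O)(=O)O[C@@]12[C@@H](CO[Si](C)(C)C(C)(C)C)O[C@@H](n1cc(C)c(=O)n(C)c1=O)[C@@H]2O[Si](C)(C)C(C)(C)C` reaches only a limit of this assay, > 250000 nM, so no number is known for it. Going by the values given here, the one step measured between neighbours, an at least 8.4-fold higher number from compound 1 to compound 2 (0.92 log units; beyond the scatter), shows that replacing the side-chain carbonyl on the amine nitrogen with a plain chain lifts the number well beyond the scatter, and that the limit of > 250000 nM in this assay, at which 1 of the 3 values shown sits, caps how far it can be followed.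

Compound 4 `Cc1cn([C@@H]2O[C@H](CO[Si](C)(C)C(C)(C)C)[C@@]3(OS(=O)(=O)C=C3NC(=O)NC(=O)c3ccccc3)[C@H]2O[Si](C)(C)C(C)(C)C)c(=O)n(C)c1=O` differs from compound 1 by benzamido in place of (methoxycarbonyl)methyl on a carbonyl carbon. This change keeps the carbonyl on the amine nitrogen that compound 2 lost, so the measured step does not bear on it directly; only the gap between compound 1 and compound 3 gives a sense of how far numbers here spread. The expected step is a 1.5-fold higher number from compound 1 to compound 4 (0.18 log units; within the scatter), a modest rise with wide uncertainty. For compound 4 in this assay the estimate is 45000 nM, between 12000 nM and 200000 nM.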

Compound 4, half-maximal cytotoxic concentration: 2290 nM
Compound 4: middle estimate off by 20-fold (1.29 log units), on the high side, outside the stated range (below it).
By their numbers in this assay, from the lowest: compound 4; then compound 1; then compound 3. At a limit, above all of these: compound 2.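

In this assay, benzamido in place of (methoxycarbonyl)methyl on a carbonyl carbon gives a 13-fold lower number from compound 1 to compound 4 (1.11 log units; beyond the scatter), so this side chain can lower the number as well as raise it. The carbonyl on the amine nitrogen is present in both compound 1 and compound 4, so that carbonyl alone does not set the number; what is attached to it matters too. Benzoylcarbamoyl in place of 2-(methoxycarbonyl)ethyl on an amine nitrogen gives an at least 100-fold lower number from compound 2 to compound 4 (2.03 log units; beyond the scatter), a step with no fixed size since compound 2 stands at a limit: the limit of > 250000 nM in this assay, at which 1 of the 4 values shown sits.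

The compounds shown leave open whether the aromatic ring or the added nitrogen of benzamido accounts for the drop, as the two enter together. A phenyl group directly on that carbonyl carbon, or an amine in place of benzamido, would help tell these apart.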